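The compounds below may be only part of what the source reports. "The series", "measured", "known", "first", "only" and "open" are said of these compounds alone.

Compound 1 `O=S(=O)(NCCCCNCc1ccc(Br)cc1)c1cc(C(F)(F)F)cc(C(F)(F)F)c1` gives 2100 nM in a functional assay on A2780 cells (Homo sapiens) for inhibition, read by MTT assay, with a stated time of 72 h; a lower number here means a stronger inhibitor of growth, a higher number a weaker inhibitor of growth.
Compound 2 `O=S(=O)(NCCCNCc1cccc(Cl)c1)c1cc(C(F)(F)F)cc(C(F)(F)F)c1` gives 2200 nM.
Compound 3 `COc1ccccc1CNCCCNS(=O)(=O)c1cc(C(F)(F)F)cc(C(F)(F)F)c1` gives 1500 nM.

Compound 3 carries the lowest of the three numbers, but the steps leading to it, a 1.4-fold lower number from compound 1 to compound 3 (0.15 log units; within the scatter) and a 1.5-fold lower number from compound 2 to compound 3 (0.17 log units; within the scatter), both lie within the scatter, as does a 1.0-fold higher number from compound 1 to compound 2 (0.02 log units; within the scatter), so none of the three can be set apart from the others.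

Compound 4 `O=S(=O)(NCCCNCc1ccc(Cl)c(Cl)c1)c1cc(C(F)(F)F)cc(C(F)(F)F)c1` differs from compound 3 in one place: 3,4-dichlorophenyl in place of 2-methoxyphenyl on a saturated chain carbon bound to an amine nitrogen. The step that bears most directly on this change is a 1.5-fold lower number from compound 2 to compound 3 (0.17 log units; within the scatter), which exchanges one chlorine-bearing phenyl for the methoxyphenyl and stays within the scatter; the halogenated benzyl groups of compound 1 and compound 2 likewise sit within the scatter of each other. Nothing in the three measurements points to a step beyond the scatter in this assay for compound 4. Compound 4 is therefore expected at about 2000 nM, with a range from 1000 nM to 4000 nM, which amounts to an expected 1.3-fold higher number from compound 3 to compound 4 (0.12 log units; within the scatter).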

Compound 4, concentration for 50% growth inhibition: 1500 nM
For compound 4 the middle estimate is 1.3-fold (0.12 log units) above the measured one, within the range that was stated.
By their numbers in this assay, from the lowest: compounds 3, 4, 1 and 2 (each within the scatter of the next).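

In this assay, the saturated chain carbon bound to an amine nitrogen carries 3,4-dichlorophenyl as readily as 2-methoxyphenyl (no change at the digits printed from compound 3 to compound 4 (within the scatter)), so a ring with no hydrogen-bond acceptor reads the same as one with an acceptor. A further chloro in place of hydrogen on an aromatic carbon (a 1.5-fold lower number from compound 2 to compound 4 (0.17 log units; within the scatter)) and (3,4-dichlorobenzyl)amino in place of ((4-bromobenzyl)amino)methyl (a 1.4-fold lower number from compound 1 to compound 4 (0.15 log units; within the scatter)) also stay within the scatter, so all four compounds now lie within the scatter of one another. No evidence is available to explain this flat result.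

Going by these compounds, whether any group at this position can move the number beyond the scatter remains open, for example a pyridine ring or a phenyl bearing a carboxylic acid. Also open, on these data alone, is how an amide in place of the amine would read.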